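From Fluoro to Acetyl on the Pendant Aryl Ring

A few compounds are considered here, and "the series" means these few. Any claim that something is new, unique, unknown or untested is made for them only; others in the source may bear on it.

Compound 1 `COc1cc(-n2cnc3ccc(-c4ccc(C(F)(F)F)cc4)cc32)cc(OC)c1OC` gives 3390 nM in a functional assay on A549 cells (Homo sapiens) for antiproliferative activity, read by MTT assay, with a stated time of 72 h; a higher number here means a weaker inhibitor, a lower number a stronger inhibitor. Compound 2 `COc1cc(-n2cnc3ccc(-c4ccc(F)cc4)cc32)cc(OC)c1OC` gives 6740 nM in this assay. Going by the values given here, compound 2 thus carries the highest of the two numbers so far, and its only neighbour is compound 1: the step of a 2.0-fold higher number from compound 1 to compound 2 (0.30 log units; within the scatter) stays within the scatter, so the two compounds cannot be ordered. Compound 3 `COc1cc(-n2cnc3ccc(-c4ccc(C(C)=O)cc4)cc32)cc(OC)c1OC` is not yet measured. Its change from compound 2 is acetyl in place of fluoro on an aromatic carbon, read one bond further out as 4-fluorophenyl to 4-acetylphenyl. Among the compounds with values here, only one measured step exists, a 2.0-fold higher number from compound 1 to compound 2 (0.30 log units; within the scatter), and it concerns a different group entering on an aromatic carbon; nothing measured bears on an acetyl group. The expectation for the step of a 1.2-fold lower number from compound 2 to compound 3 (0.09 log units; within the scatter) is therefore no movement beyond the scatter. Compound 3 is estimated at 5500 nM in this assay, with a range from 1500 nM to 20000 nM.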

Compound 3, half-maximal inhibitory concentration: 2510 nM
Compound 3: middle estimate off by 2.2-fold (0.34 log units), on the high side; measured number inside the range.
By their numbers in this assay, from the lowest: compounds 3, 1 and 2 (each within the scatter of the next, the first and the last beyond it).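

In this assay, this place on the aromatic ring, para to a large group, now shows a step beyond the scatter: acetyl in place of fluoro gives a 2.7-fold lower number from compound 2 to compound 3 (0.43 log units; beyond the scatter) and the size of this step is modest. Acetyl in place of trifluoromethyl gives a 1.4-fold lower number from compound 1 to compound 3 (0.13 log units; within the scatter) and leaves compound 1 and compound 3 unordered, so the acetyl group stands clear of fluoro only, and not of both groups it replaced. No measurement at hand accounts for the step from fluoro to acetyl.

The compounds shown leave open whether a carboxylic acid, an amide or an amine at this place would move the number further than acetyl does. They also leave open whether a longer ketone chain would keep, lose or extend the step seen with acetyl.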